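A methoxy group added to compound 3

The source may report more compounds than this note shows. Statements on the series, on what has been measured and on what is new or still open speak of the compounds shown alone.

In a functional assay on HCT-116 cells (Homo sapiens) for inhibition, read by sulforhodamine B assay, with a stated time of 48 h, tested at 50 uM (on this read-out higher numbers stand for more inhibition of growth at the one concentration tested and lower numbers for less inhibition of growth), compound 1 `COc1cc(/C=C/C(=O)/C=C/c2cccc3ccccc23)ccc1OCc1cn(CCOc2cc(=O)oc3ccccc23)nn1`, which carries a naphthalen-1-yl group, gives 83% on this measure. Compound 2 `COc1cccc(/C=C/C(=O)/C=C/c2ccc(OCc3cn(CCOc4cc(=O)oc5ccccc45)nn3)c(OC)c2)c1` has a 3-methoxyphenyl group in that place and gives 70% here. Compound 3 `COc1cc(/C=C/C(=O)/C=C/c2ccccc2)ccc1OCc1cn(CCOc2cc(=O)oc3ccccc23)nn1` has plain phenyl there and gives 56% as the lowest of the three.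

Compound 4 `COc1ccc(/C=C/C(=O)/C=C/c2ccc(OCc3cn(CCOc4cc(=O)oc5ccccc45)nn3)c(OC)c2)cc1` is still unmeasured. It has methoxy in place of hydrogen on an aromatic carbon, para to a large group (methoxy in place of hydrogen on an aromatic carbon), which turns the phenyl of compound 3 into 4-methoxyphenyl.

Read in reverse, the closest precedent (a number 14 percentage points lower from compound 2 to compound 3 (beyond the scatter)) suggests that adding methoxy to phenyl may raise the number modestly. The larger step (a number 27 percentage points lower from compound 1 to compound 3 (beyond the scatter)) shows that this part of the molecule can shift the read-out. For the measured compounds named here, no measured compound carries 4-methoxyphenyl, so the size remains uncertain.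

In this assay the expected change is a modest rise (a number 12 percentage points higher from compound 3 to compound 4 (beyond the scatter)). The estimated value for compound 4 is 68% within an expected range (52% to 82%).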

Compound 4, percent growth inhibition at one concentration: 71%
Compound 4: middle estimate off by 3 percentage points, on the low side; the measured number falls inside the stated range.
By their numbers in this assay, from the lowest: compound 3; then compounds 2 and 4 (each within the scatter of the next); then compound 1.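

In this assay, a methoxy group on the phenyl ring, para to a large group, raises growth inhibition (a number 15 percentage points higher from compound 3 to compound 4 (beyond the scatter)), so the gain seen with 3-methoxyphenyl is not confined to that one placement. Moving the methoxy group from the 3-methoxyphenyl arrangement to 4-methoxyphenyl makes no readable difference (a number 1 percentage points higher from compound 2 to compound 4 (within the scatter)), and this assay does not separate the two placements. Even so, 4-methoxyphenyl does not match naphthalen-1-yl (a number 12 percentage points lower from compound 1 to compound 4 (beyond the scatter)), which keeps the larger ring system ahead of either methoxy-bearing phenyl.

On these data alone, whether a hydroxyl group, an amine or a longer ethoxy chain at this place on the ring would give a similar number remains open. The compounds shown also give no measurement that explains any of these shifts.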